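Swapping Methoxy for Bromo: What to Expect

The compounds below may be only part of what the source reports. "The series", "measured", "known", "first", "only" and "open" are said of these compounds alone.

Measured so far in a functional assay on MCF7 cells (Homo sapiens) for antiproliferative activity, read by MTT assay, with a stated time of 48 h; a higher number here means a weaker inhibitor, a lower number a stronger inhibitor:
- compound 1 `COc1ccc(/C=C/C(=O)Nc2nnc(-c3ccccc3)s2)cc1`: 0.83 ug/mL
- compound 2 `COc1ccc(/C=C/C(=O)Nc2nnc(-c3ccc(OC)cc3)s2)cc1`: 0.28 ug/mL

Of these two compounds, compound 2 has the lower number, 0.28 ug/mL, and so stands as the stronger inhibitor. The next compound, compound 3 `COc1ccc(/C=C/C(=O)Nc2nnc(-c3ccc(Br)cc3)s2)cc1`, keeps the shared core but carries a different group: bromo in place of methoxy on an aromatic carbon. In short, this is bromo in place of methoxy on an aromatic carbon.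

For the measured compounds named here, only one measured step bears on this change. It is a 3.0-fold lower number from compound 1 to compound 2 (0.47 log units; beyond the scatter), a modest step that came with methoxy in place of hydrogen on an aromatic carbon. Going by the values given here, no measured compound carries bromo, so the data cannot show whether it will behave more like hydrogen or more like methoxy. Losing the methoxy group may give back part or all of the gain seen in that step, so a modest move toward a higher number seems more likely than a further fall. The expected change in this assay is a 2.1-fold higher number from compound 2 to compound 3 (0.33 log units; beyond the scatter). Compound 3 is estimated at 0.6 ug/mL, with an expected range from 0.2 ug/mL to 1.6 ug/mL.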

Compound 3, half-maximal inhibitory concentration: 1.13 ug/mL
The estimate for compound 3 lay 1.9-fold (0.27 log units) below the measured number; the range from low to high includes it.
By their numbers in this assay, from the lowest: compound 2; then compounds 1 and 3 (each within the scatter of the next).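

In this assay, the fall in the number that came with methoxy does not extend to the other group placed here: a 4.0-fold higher number from compound 2 to compound 3 (0.61 log units; beyond the scatter), a step beyond the scatter, so bromo does not stand in for methoxy at this position. Compared with the compound that carries only hydrogen at this place, the bromo compound shows a 1.4-fold higher number from compound 1 to compound 3 (0.13 log units; within the scatter), which lies within the scatter, so no change can be read from putting bromo on this aromatic carbon in place of hydrogen. Among the three compounds, then, only compound 2 stands apart from both others by steps beyond the scatter, and a group at this place does not by itself lower the number. Nothing given here accounts for the difference between methoxy and bromo at this position.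

The compounds shown leave open whether the lower number of compound 2 would hold with a hydroxy group, an ethoxy group or an amine at this place. They also leave open whether chloro or fluoro would read like bromo, or whether either would move the number away from that of compound 3.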